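The source may report more compounds than this note shows. Statements on the series, on what has been measured and on what is new or still open speak of the compounds shown alone.

Measured so far:
compound 1, `CNc1nc(NCc2ccc(OC(F)(F)F)cc2)cc(-c2ccccn2)n1`: 7 nM
compound 2, `CNc1nc(NCc2ccc(NC(C)=O)cc2)cc(-c2ccccn2)n1`: 2 nM

In a functional assay on HEK293 cells for agonist activity at G-protein coupled receptor 39 (Mus musculus), read by inositol phosphate accumulation (a higher number here means that more compound is needed for the effect, a lower number that less compound is needed), compound 2 gives 2 nM, the lower of the two numbers recorded, and compound 1 gives 7 nM in this assay. Within the data shown here, the only step within the measured pair is a 3.5-fold lower number from compound 1 to compound 2 (0.54 log units; beyond the scatter), a modest move that lies beyond the scatter.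

Compound 3, `CNc1nc(NCc2ccc(NS(C)(=O)=O)cc2)cc(-c2ccccn2)n1`, is not yet measured. It differs from compound 2 by methylsulfonyl in place of acetyl on a nitrogen on an aromatic ring; read one bond further out, the change is acetamido to methanesulfonamido, the site being a nitrogen on an aromatic ring whose other neighbours are aromatic carbon. Among the measured compounds shown here, no measured step exchanges one group on that nitrogen for another, so the step from compound 1 to compound 2 bears on it only indirectly, by showing which end of the series compound 2 occupies. The expected step is a 1.5-fold higher number from compound 2 to compound 3 (0.18 log units; within the scatter), within the scatter. Compound 3 is estimated at 3 nM, with a range from 1 nM to 10 nM.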

Compound 3, half-maximal effective concentration: 8 nM
The estimate for compound 3 lay 2.7-fold (0.43 log units) below the measured number; measured number inside the range.
By their numbers in this assay, from the lowest: compound 2; then compounds 1 and 3 (each within the scatter of the next).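

At a nitrogen on an aromatic ring, the exchange of acetyl for methylsulfonyl is not silent in this assay: the series now has a direct reading of a change on that nitrogen, a 4.0-fold higher number from compound 2 to compound 3 (0.60 log units; beyond the scatter). Nitrogen-linked substitution as such does not carry the lower number, since a 1.1-fold higher number from compound 1 to compound 3 (0.06 log units; within the scatter) leaves methanesulfonamido and trifluoromethoxy indistinguishable; among these three groups, only acetamido stands apart. Nothing available explains the difference between acetyl and methylsulfonyl at this site.

A longer acyl chain such as propanoyl, a urea or a free amine on that nitrogen would show whether the acetyl group itself matters or a wider range of groups reads alike. The exchange is also shown on one core only, so its size with other parts of the structure changed remains open.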